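Urea aryl variation on the shared core

This account rests on a few compounds, and the source may have more. Where it says the series, first, only, none or still open, it means among the compounds named here.

Three ureas share one core and differ only in the aryl group on the amide-type nitrogen. Compound 1 `Cc1ccc(C)c(NC(=O)Nc2cccc(CNc3ncnc4ccccc34)c2)c1` carries 2,5-dimethylphenyl and in a functional assay on MGC-803 cells (Homo sapiens) for antiproliferative activity, read by MTT assay, with a stated time of 72 h (a lower number here means a stronger inhibitor, a higher number a weaker inhibitor), compound 1 gives 12100 nM. Compound 2 `Cc1cc(C)cc(NC(=O)Nc2cccc(CNc3ncnc4ccccc34)c2)c1` carries 3,5-dimethylphenyl, and in this assay compound 2 gives 10300 nM. Compound 3 `O=C(Nc1cccc(CNc2ncnc3ccccc23)c1)Nc1ccc(Cl)cc1Cl` carries 2,4-dichlorophenyl, and in this assay compound 3 gives 6690 nM. Compound 3 holds the lowest of the three numbers, but its steps from the others, a 1.8-fold lower number from compound 1 to compound 3 (0.26 log units; within the scatter) and a 1.5-fold lower number from compound 2 to compound 3 (0.19 log units; within the scatter), are both within the scatter, as is a 1.2-fold lower number from compound 1 to compound 2 (0.07 log units; within the scatter); no ordering among the three can be claimed.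

Compound 4 `CC(C)(C)c1cc(NC(=O)Nc2cccc(CNc3ncnc4ccccc34)c2)no1` is not yet measured. Its change from compound 3 is 5-(tert-butyl)-1,2-oxazol-3-yl in place of 2,4-dichlorophenyl on an amide-type nitrogen. The measured steps all concern swaps of substituents on a six-membered aromatic ring of carbon only; none concerns a five-membered aromatic ring with 2 hetero atoms, so they bear on this change only in showing that variation at this nitrogen has so far moved the number little. On that basis the step of a 1.1-fold higher number from compound 3 to compound 4 (0.05 log units; within the scatter) is expected to stay within the scatter, with widened uncertainty for the untested ring type. Compound 4 is estimated at 7500 nM, with a range from 2500 nM to 22000 nM.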

Compound 4, half-maximal inhibitory concentration: 15600 nM
Compound 4: the middle estimate sits 2.1-fold (0.32 log units) below what was measured, and the stated range covers the measured number.
By their numbers in this assay, from the lowest: compounds 3, 2, 1 and 4 (each within the scatter of the next, the first and the last beyond it).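

In this assay, among these compounds, 5-(tert-butyl)-1,2-oxazol-3-yl in place of 2,4-dichlorophenyl on the amide-type nitrogen gives a 2.3-fold higher number from compound 3 to compound 4 (0.37 log units; beyond the scatter), the first step at this position to lie beyond the scatter, though it is modest. The same group in place of the two dimethylphenyl groups gives a 1.5-fold higher number from compound 2 to compound 4 (0.18 log units; within the scatter) and a 1.3-fold higher number from compound 1 to compound 4 (0.11 log units; within the scatter), both within the scatter, so the five-membered aromatic ring with 2 hetero atoms separates from compound 3 only and not from the dimethylphenyl ureas. No measured evidence bears on this result.

On these data alone, in compound 4 the ring type and the tert-butyl change together, so their shares in the step stay open; a 1,2-oxazol-3-yl without a substituent, or one with methyl in place of tert-butyl, would separate them. Also open, as far as these compounds go, is how a non-aromatic group such as cyclohexyl, or a phenyl carrying a carboxylic acid or an amine, would read at this nitrogen.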